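Chloro to Methyl on the Shared Core: Cytotoxicity Outlook

This account rests on a few compounds, and the source may have more. Where it says the series, first, only, none or still open, it means among the compounds named here.

Compound 1 `Cn1nc(-c2nnc(-c3ccccc3Cl)o2)c2ccccc21` gives > 100000 nM in an ADME assay on L02 cells (Homo sapiens) for cytotoxicity, read by MTT assay, with a stated time of 72 h (a higher number here means a weaker inhibitor, a lower number a stronger inhibitor), which is a limit of the assay and not a number.
Compound 2 `COc1ccc(-c2nnc(-c3nn(C)c4ccccc34)o2)cc1` gives > 100000 nM in this assay, again a limit of the assay.
Compound 3 `Cn1nc(-c2nnc(-c3cccc(Cl)c3)o2)c2ccccc21` gives > 100000 nM in this assay, also a limit of the assay.

All three measured compounds share (the limit of > 100000 nM in this assay, at which 3 of the 3 values shown sit), so compound 3 cannot be placed above or below its companions on the numbers available. Compound 4 `Cc1cccc(-c2nnc(-c3nn(C)c4ccccc34)o2)c1` differs from compound 3 by a single exchange (methyl in place of chloro on an aromatic carbon); cut one bond further out, this reads 3-chlorophenyl to 3-methylphenyl. Among the measured compounds shown here, the one measured step that touches this ring, a step that the two limits leave unreadable from compound 1 to compound 3, has no readable size: both of its ends are limits. For the measured compounds named here, nothing measured so far shows any movement in this assay for changes on this ring. The expected step that the limit leaves unreadable from compound 3 to compound 4 is therefore none beyond the scatter. Compound 4 is expected most likely to return another limit rather than a number. On that basis compound 4 is estimated at 150000 nM, within a range from 60000 nM to 500000 nM.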

Compound 4, half-maximal inhibitory concentration: > 100000 nM
Compound 4 gave a limit, no number; the forecaster's own chance of this, stated with the estimate: 85%; the middle value is on the limit's open side.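

Neither step from compound 3 to compound 4 nor from compound 1 to compound 4 can be read, because all these compounds end at a limit of the assay, not a number: the limit of > 100000 nM in this assay, at which 4 of the 4 values shown sit.

The compounds shown leave open whether methyl and chloro on this ring differ at all in this assay.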